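A few compounds are considered here, and "the series" means these few. Any claim that something is new, unique, unknown or untested is made for them only; others in the source may bear on it.

In an ADME assay (liver) for metabolic stability, with Liver microsome (Homo sapiens) as the target, read by LC-MS, using microsomes and NADPH, with a stated time of 5 min, at 37 degrees C (on this read-out lower numbers stand for slow clearance and higher numbers for fast clearance), compound 2 `CCn1c([C@@H](C)NS(=O)(=O)C2CC2)nc2ccc(C(F)(F)F)cc21` gives < 3 mL.min-1.g-1, which is a limit of the assay and not a number. Within the data shown here, the only other measured compound, compound 1 `CCn1c([C@@H](C)NS(=O)(=O)c2ccc(Cl)cc2)nc2cc(CO)ccc21`, gives 88 mL.min-1.g-1 in this assay. Compound 3 `CCn1c([C@@H](C)NS(=O)(=O)c2ccc(CC(C)C)cc2)nc2ccc(C(F)(F)F)cc21` has not yet been measured. It differs from compound 2 in one place, with 4-isobutylphenyl in place of cyclopropyl on a sulfonyl sulfur. Among the measured compounds shown here, no measured pair isolates this change. For the measured compounds named here, compound 1 also carries a six-membered aromatic ring on its sulfonyl sulfur, and its 88 mL.min-1.g-1 is the only guide, although it differs from compound 3 elsewhere as well. The change is therefore expected to be towards faster clearance and beyond the usual scatter, an estimated at least 13-fold higher number from compound 2 to compound 3 (1.12 log units; beyond the scatter). Compound 3 is estimated at 40 mL.min-1.g-1, with an expected range of 10 mL.min-1.g-1 to 120 mL.min-1.g-1.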

Compound 3, intrinsic clearance in microsomes: > 100 mL.min-1.g-1
Compound 3: only a limit was reported (the forecaster's own chance of this, stated with the estimate: 5%); middle value at least 2.5-fold (0.39 log units) away from the limit.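

In this assay, changing the group on the sulfonyl sulfur alone, with the rest of the molecule held constant, carries the read-out from one limit of the assay to the other, and 4-isobutylphenyl in place of cyclopropyl gives an at least 33-fold higher number from compound 2 to compound 3 (1.52 log units; beyond the scatter). Among these compounds, this is the first pair to isolate the change, since compound 1 also differs from compound 3 elsewhere. The step is only a minimum and its true size stays unknown, because compound 3 stands at a limit of the assay, as compound 2 does at the opposite end: the limit of > 100 mL.min-1.g-1 in this assay, at which 1 of the 3 values shown sits.

On these data alone, it remains open whether the step comes from the aromatic ring itself or from the isobutyl chain it carries. As far as these compounds go, how a plain phenyl, or a phenyl bearing an amine or a carboxylic acid, would read in this assay also remains open.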